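Chain extension on the ethoxyphenyl side of a chromone core

The source may report more compounds than this note shows. Statements on the series, on what has been measured and on what is new or still open speak of the compounds shown alone.

Compound 1 `CCC1=C(O)c2c(oc(-c3ccc(CC)cc3)cc2=O)C(CC)(CC)C1=O` gives 0.07 uM in a functional assay on KBVIN cells (Homo sapiens) for antiproliferative activity, read by sulforhodamine B assay, with a stated time of 3 days; on this read-out lower numbers stand for an effect already at smaller amounts and higher numbers for an effect only at larger amounts of compound. Compound 2 `CCC1=C(O)c2c(oc(-c3ccc(C(C)C)cc3)cc2=O)C(CC)(CC)C1=O` carries methyl in place of hydrogen on a saturated chain carbon bound to an aromatic carbon and a saturated chain carbon and gives 1.08 uM, so the step is a 15-fold higher number from compound 1 to compound 2 (1.19 log units; beyond the scatter). Compound 3 `CCOc1ccc(-c2cc(=O)c3c(o2)C(CC)(CC)C(=O)C(CC)=C3O)cc1` differs from compound 1 in its core by ethoxy in place of ethyl on an aromatic carbon. Compound 3 gives 7.54 uM, which is a 110-fold higher number from compound 1 to compound 3 (2.03 log units; beyond the scatter). Compound 4 `CCCOc1ccc(-c2cc(=O)c3c(o2)C(CC)(CC)C(=O)C(CC)=C3O)cc1` is not yet measured; it carries methyl in place of hydrogen on a saturated chain carbon, two bonds along the chain from an oxygen on an aromatic ring, the same kind of change as that from compound 1 to compound 2, but here the new methyl sits on a saturated chain carbon two bonds along the chain from an oxygen on an aromatic ring rather than on a carbon bound to an aromatic carbon. A smaller step is therefore expected, estimated at a 2.0-fold higher number from compound 3 to compound 4 (0.30 log units; within the scatter), because the earlier step was a 15-fold higher number from compound 1 to compound 2 (1.19 log units; beyond the scatter) at a different place. Compound 4 is expected to give about 15 uM, within 5 uM to 45 uM.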

Compound 4, concentration for half-maximal effect: 29.2 uM
Compound 4: the middle estimate sits 1.9-fold (0.29 log units) below what was measured, and the stated range covers the measured number.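

Adding the methyl that turns ethoxy into propoxy gives a 3.9-fold higher number from compound 3 to compound 4 (0.59 log units; beyond the scatter) in this assay, so the change moves the number in the same direction on both cores, but not by the same amount: the same change on two cores in this assay, a 15-fold higher number (1.19 log units; beyond the scatter) from compound 1 to compound 2 and a 3.9-fold higher number (0.59 log units; beyond the scatter) from compound 3 to compound 4, 4.0-fold (0.60 log units) apart, beyond the scatter of two such steps

Compound 4 also lies far from the other two compounds, with a 27-fold higher number from compound 2 to compound 4 (1.43 log units; beyond the scatter) and a 420-fold higher number from compound 1 to compound 4 (2.62 log units; beyond the scatter). Two pairs show that the direction held in these compounds, but they do not show that it would hold on other cores, and they do not explain the difference in size.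

Still open, as far as these compounds go, is whether a longer chain such as butoxy would continue this trend, and how an amine in place of the propoxy would behave.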